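Swapping Chloro for Cyano at the Slow-Clearance End

The source may hold more compounds than are shown below. What is called first, only, known or untested is meant among the compounds shown, and "the series" means these compounds.

In an ADME assay on microsomes from liver (Homo sapiens) for metabolic stability (on this read-out higher numbers stand for fast clearance and lower numbers for slow clearance), three compounds sharing a core have been measured. Compound 1 `CCn1cnc2c(-c3ccnc(Oc4ccccc4)c3)cnnc21` gives 51 mL.min-1.g-1 and compound 2 `CCn1cnc2c(-c3ccc(F)c(-c4ccc(S(=O)(=O)CC)cc4Cl)c3)cnnc21` gives 9 mL.min-1.g-1 on this read-out.

Compound 3 `CCn1cnc2c(-c3ccc(Cl)c(-c4ccc(S(=O)(=O)CC)cc4OC)c3)cnnc21` reads < 8 mL.min-1.g-1 and this is a limit of the assay, not a number. Compound 3 therefore sits at the limit of < 8 mL.min-1.g-1 in this assay, at which 1 of the 3 values shown sits, in this small set. That places it at the slow end of the three together with compound 2, while compound 1 lies far higher.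

Compound 4 `CCn1cnc2c(-c3ccc(C#N)c(-c4ccc(S(=O)(=O)CC)cc4OC)c3)cnnc21` differs from compound 3 in one place, with cyano in place of chloro on an aromatic carbon, ortho to a large group and para to a large group. The change counts as cyano in place of chloro on an aromatic carbon and the rest of the structure stays the same.

For the measured compounds named here, no two measured compounds differ in only one place, so the size of this step in this assay can only be expected, not read off. The expectation of a low number leans on compound 2 at 9 mL.min-1.g-1 as a second low result. The expected change a number no lower from compound 3 to compound 4 (the limit leaves the size open) stays within the usual scatter and has no clear direction.

For compound 4 the estimated clearance is 8 mL.min-1.g-1 with an expected range from 4 mL.min-1.g-1 to 16 mL.min-1.g-1 as the likely span.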

Compound 4, intrinsic clearance in microsomes: < 8 mL.min-1.g-1
Compound 4: only a limit was reported (the forecaster's own chance of this, stated with the estimate: 55%); the middle value lies on the limit itself.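

In this assay compound 4 reads < 8 mL.min-1.g-1 as a limit of the assay, not a number. Compound 3 also stands at a limit, so no step can be read between compound 3 and compound 4. The compounds shown leave open whether cyano in place of chloro shifts clearance at all, and in which direction.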